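The compounds below may be only part of what the source reports. "The series", "measured", "known", "first", "only" and "open" are said of these compounds alone.

Compound 1 `COC(=O)N1N=C(c2cccc(OC)c2)CC1c1cc(OC)c(OC)c(OC)c1`: 2590 nM
Compound 2 `CCOc1cccc(C2=NN(C(=O)OC)C(c3cc(OC)c(OC)c(OC)c3)C2)c1`: 5290 nM

In a functional assay on A549 cells (Homo sapiens) for antiproliferative activity, read by MTT assay, with a stated time of 48 h (a lower number here means a stronger inhibitor of growth, a higher number a weaker inhibitor of growth), compound 2 gives 5290 nM, the higher of the two numbers. Compound 3 `COC(=O)N1N=C(c2cccc(C)c2)CC1c1cc(OC)c(OC)c(OC)c1` keeps the shared core but has methyl in place of ethoxy on an aromatic carbon. For the measured compounds named here, only one measured step bears on this, a different change and so a rough guide: a 2.0-fold higher number from compound 1 to compound 2 (0.31 log units; beyond the scatter). It is modest and came from methyl in place of hydrogen on a saturated chain carbon bound to an oxygen on an aromatic ring. A modest move toward a lower number is therefore expected, namely a 1.8-fold lower number from compound 2 to compound 3 (0.25 log units; within the scatter). For compound 3 the estimated value is 3000 nM, with an expected range of 1200 nM to 8000 nM.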

Compound 3, concentration for 50% growth inhibition: 300 nM
Compound 3: the middle estimate sits 10-fold (1.00 log units) above what was measured, outside the stated range (below it).
By their numbers in this assay, from the lowest: compound 3; then compound 1; then compound 2.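

In this assay, swapping the oxygen-linked group on this ring carbon for methyl gives an 18-fold lower number from compound 2 to compound 3 (1.25 log units; beyond the scatter) and also an 8.6-fold lower number from compound 1 to compound 3 (0.94 log units; beyond the scatter). Both steps are larger than the earlier change within the oxygen-linked chain, so the direct swap to methyl matters more here than that change did. No evidence here explains the gain. The compounds shown leave open whether methyl is the best choice at this place, or whether an ethyl chain, a chlorine atom or plain hydrogen would match it. They also leave open whether methyl would help elsewhere on this ring.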